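Shortening and Branching the Hydroxamic Acid Chain

A few compounds are considered here, and "the series" means these few. Any claim that something is new, unique, unknown or untested is made for them only; others in the source may bear on it.

Among the measured compounds shown here, compound 1 `O=C(CCCOc1no[n+]([O-])c1S(=O)(=O)c1ccccc1)NO` is one of two compounds so far measured in a functional assay on ES2 cells (Homo sapiens) for inhibition, read by MTT assay, with a stated time of 48 h; a lower number here means a stronger inhibitor, a higher number a weaker inhibitor; there compound 1 gives 3780 nM, the highest of the two numbers. For the measured compounds named here, its only neighbour is compound 2 `O=C(CCCCCCCOc1no[n+]([O-])c1S(=O)(=O)c1ccccc1)NO`, which in this assay gives 1320 nM, so that there is a 2.9-fold lower number from compound 1 to compound 2 (0.46 log units; beyond the scatter). Compound 3 `CC(C)(COc1no[n+]([O-])c1S(=O)(=O)c1ccccc1)C(=O)NO` has not yet been measured. It differs from compound 1 by 1-(hydroxycarbamoyl)-1-methylethyl in place of 2-(hydroxycarbamoyl)ethyl on a saturated chain carbon bound to an oxygen on an aromatic ring. Going by the values given here, only one measured step bears on this change, and that step shows that lengthening the chain between the aromatic oxygen and the hydroxamic acid brought a modestly lower number. Among the compounds with values here, the change to compound 3 goes the other way, toward a shorter chain, and also adds branching, which no measured pair tests. The expectation is therefore a modest step toward a higher number, a 1.7-fold higher number from compound 1 to compound 3 (0.24 log units; within the scatter). Compound 3 is estimated to give 6500 nM in this assay, within a range from 2500 nM to 17000 nM.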

Compound 3, half-maximal inhibitory concentration: 6880 nM
Estimate against measurement, compound 3: 1.1-fold (0.02 log units) below; measured number inside the range.
By their numbers in this assay, from the lowest: compound 2; then compounds 1 and 3 (each within the scatter of the next).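

In this assay, putting 1-(hydroxycarbamoyl)-1-methylethyl in place of 2-(hydroxycarbamoyl)ethyl gives a 1.8-fold higher number from compound 1 to compound 3 (0.26 log units; within the scatter), so this assay does not tell the two compounds apart. The earlier compounds shown here tested only a change in the length of an unbranched chain, whereas this result shows that a branched group can stand at this place on the saturated chain carbon without a change beyond the scatter. Nothing available explains the result.

Going by these compounds, since this one change both shortens and branches the chain, the effect of each alone remains unknown. Also open, on these data alone, are how an unbranched chain of the same shortened length would read, and whether a carboxylic acid could take the place of the hydroxamic acid.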